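The compounds below may be only part of what the source reports. "The series", "measured", "known", "first", "only" and "open" are said of these compounds alone.

Measured compounds:
Compound 1, `COc1cc(N)c(Cl)cc1C(=O)NC1CCN(CC2CCN(C(=O)CCCN)CC2)CC1`, gives 3.99 nM in an assay on striatum for inhibition of 5-hydroxytryptamine receptor 4 (Cavia porcellus), read by radioligand binding; a lower number here means a stronger inhibitor, a higher number a weaker inhibitor.
Compound 2, `CCCC(N)C(=O)N1CCC(CN2CCC(NC(=O)c3cc(Cl)c(N)cc3OC)CC2)CC1`, gives 2.57 nM.
Compound 3, `COc1cc(N)c(Cl)cc1C(=O)NC1CCN(CC2CCN(C(=O)CN)CC2)CC1`, gives 9.3 nM.

Within this small set compound 1 sits in the middle: compound 2 comes out lower by a 1.6-fold lower number from compound 1 to compound 2 (0.19 log units; within the scatter), a difference inside the usual scatter, while compound 3 comes out higher by a 2.3-fold higher number from compound 1 to compound 3 (0.37 log units; beyond the scatter), a modest step beyond it. Between compound 2 and compound 3 the step is a 3.6-fold higher number from compound 2 to compound 3 (0.56 log units; beyond the scatter), again modest.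

Compound 4, `COc1cc(N)c(Cl)cc1C(=O)NC1CCN(CC2CCN(CC(O)CN)CC2)CC1`, differs from compound 1 in one place: 3-amino-2-hydroxypropyl in place of (3-aminopropyl)carbonyl on an amine nitrogen in a ring. For the measured compounds named here, no measured step removes the carbonyl in this way; the steps seen so far only change the length or branching of the amine-bearing chain, and those changes moved the numbers modestly at most. The change to compound 4 is larger in kind, so a somewhat weaker result seems the safer expectation, though a near-unchanged number would not be surprising.

Compound 4 is therefore estimated at 7 nM, within a range from 2.5 nM to 25 nM, an expected step of a 1.8-fold higher number from compound 1 to compound 4 (0.24 log units; within the scatter).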

Compound 4, half-maximal inhibitory concentration: 14.4 nM
For compound 4 the middle estimate is 2.1-fold (0.31 log units) below the measured one; low and high end bracket the measured number.
By their numbers in this assay, from the lowest: compounds 2 and 1 (each within the scatter of the next); then compounds 3 and 4 (each within the scatter of the next).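

For the compounds shown here, removing the carbonyl from this amine nitrogen in a ring, the one kind of change the earlier compounds did not make, has a modest cost in this assay: the step is a 3.6-fold higher number from compound 1 to compound 4 (0.56 log units; beyond the scatter), and against the branched chain it is a 5.6-fold higher number from compound 2 to compound 4 (0.75 log units; beyond the scatter). Against the short (aminomethyl)carbonyl group, however, the step is only a 1.5-fold higher number from compound 3 to compound 4 (0.19 log units; within the scatter), so the 3-amino-2-hydroxypropyl group cannot be told apart from that group here. No measurement on hand explains these differences.

A plain 3-aminopropyl group on that nitrogen would help separate the part played by the lost carbonyl from that of the added hydroxyl. Going by these compounds, whether the amine of these chains is needed at all also stays open, and an acetyl group on that nitrogen would speak to it.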